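The source may report more compounds than this note shows. Statements on the series, on what has been measured and on what is new or still open speak of the compounds shown alone.

Compound 1, `Nc1sc2c(c1C(=O)c1ccc(Br)c3ccccc13)CCC2`, gives 0% in an assay on isolated protein with adenosine receptor A1 (Homo sapiens) as the target, tested at 10 uM; on this read-out higher numbers stand for more inhibition at the one concentration tested (going by the name of the read-out) and lower numbers for less inhibition. Compound 2, `Nc1sc2c(c1C(=O)c1ccc(I)c3ccccc13)CCC2`, gives 3.3% in this assay. The change between them, (iodo in place of bromo on an aromatic carbon), made a step of a number 3.3 percentage points higher from compound 1 to compound 2 (within the scatter). Compound 3, `Nc1sc2c(c1C(=O)c1ccc(Br)c3ccccc13)CCCC2`, carries a different core; how the two cores differ is not broken down here. In this assay compound 3 gives 12%, the highest of the three numbers, beyond the scatter from compound 1 and within the scatter of compound 2. Compound 4, `Nc1sc2c(c1C(=O)c1ccc(I)c3ccccc13)CCCC2`, differs from compound 3 by iodo in place of bromo on an aromatic carbon, the same change as from compound 1 to compound 2. A step of about a number 3 percentage points higher from compound 3 to compound 4 (within the scatter) is expected in this assay, because the earlier step was a number 3.3 percentage points higher from compound 1 to compound 2 (within the scatter). Compound 4 is therefore estimated at 15%, between 2% and 28%.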

Compound 4, a percentage reported as inhibition, at one concentration (the size of the read-out at that concentration, not a potency): 15.3%
Beside the measured number, compound 4's estimate is 0.3 percentage points below it; the range from low to high includes it.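

In this assay, iodo in place of bromo on an aromatic carbon gave a step of a number 3.3 percentage points higher from compound 3 to compound 4 (within the scatter). Set beside the earlier step, the change reads the same on both cores: the same change on two cores in this assay, a number 3.3 percentage points higher (within the scatter) from compound 1 to compound 2 and a number 3.3 percentage points higher (within the scatter) from compound 3 to compound 4, 0 percentage points apart, within the scatter of two such steps. Among the compounds shown here, both steps lie within the scatter, so the series shows only that this change moved the number by no readable amount on either core, not that it has a real effect that carries from one core to another, and the comparison rests on just two cores and this one change.

The compounds shown leave open what chloro, methyl or methoxy would do at this place on the ring. They also leave open whether an amine or a carboxylic acid there would give a step beyond the scatter.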